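A few compounds are considered here, and "the series" means these few. Any claim that something is new, unique, unknown or untested is made for them only; others in the source may bear on it.

Measured so far:
Compound 1, `CCOC(=O)[C@@H]1CCC[C@@H](S(=O)(=O)c2ccc(S(=O)(=O)N(CC)CC)cc2)C1`: > 10000 nM
Compound 2, `CCCN(CCC)S(=O)(=O)c1ccc(S(=O)(=O)N2CCC[C@@H](C(=O)OCC)C2)cc1`: > 10000 nM
Compound 3, `CCN(CC)S(=O)(=O)c1ccc(S(=O)(=O)N2CCC[C@@H](C(=O)NC3CN(C(=O)C4CC4)C3)C2)cc1`: > 10000 nM

Each of these three values in a functional assay on MIA PaCa-2 cells (Homo sapiens) for inhibition, read by MTT assay, with a stated time of 3 days (on this read-out higher numbers stand for weaker inhibition and lower numbers for stronger inhibition), is a limit of the assay and not a number. The value of compound 3 is such a limit. So is the value of compound 1. So is the value of compound 2. For the measured compounds named here, all three sit at the limit of > 10000 nM in this assay, at which 3 of the 3 values shown sit, so compound 3 cannot be placed in order against the other two; nothing in the numbers separates any pair of them, and no measured step exists.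

Compound 4, `CCN1CC(NC(=O)[C@@H]2CCCN(S(=O)(=O)c3ccc(S(=O)(=O)N(CC)CC)cc3)C2)C1`, is not yet measured. It differs from compound 3 in one place: ethyl in place of cyclopropylcarbonyl on an amine nitrogen in a ring. Going by the values given here, no measured pair shows what such an exchange does, so the expected step from compound 3 to compound 4 is a step that the limit leaves unreadable from compound 3 to compound 4, that is, no change beyond the scatter, with the most likely outcome being another limit rather than a number. On that basis compound 4 is estimated at 15000 nM, with a range from 4000 nM to 60000 nM, the estimate resting only on compound 3 and its limit > 10000 nM.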

Compound 4, half-maximal inhibitory concentration: > 10000 nM
Compound 4: no number, only a limit; the forecaster's own chance of this, stated with the estimate: 80%; the middle value is on the limit's open side.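

In this assay compound 4 gives > 10000 nM, which is a limit of the assay. Compound 3 also stands at a limit, and no step can be read between compound 3 and compound 4. The compounds shown leave open what ethyl in place of cyclopropylcarbonyl does and which structures, if any, would give a number, with every value so far at one limit: the limit of > 10000 nM in this assay, at which 4 of the 4 values shown sit.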